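The compounds below may be only part of what the source reports. "The series", "measured", "known", "first", "only" and "open" are said of these compounds alone.

Compound 1, `Cc1cc(O)c(C2=NN(c3ccc(S(N)(=O)=O)cc3)C(c3ccccc3O)C2)cc1Cl`: in a functional assay on HT-29 cells (Homo sapiens) for antiproliferative activity, with a stated time of 48 h (on this read-out lower numbers stand for stronger inhibition of growth and higher numbers for weaker inhibition of growth), compound 1 gives 5100 nM.
Compound 2, `Cc1cc(O)c(C2=NN(c3ccc(S(N)(=O)=O)cc3)C(c3ccccc3Cl)C2)cc1Cl`: in this assay compound 2 gives 3630 nM.
Compound 3, `COc1ccc(C2CC(c3cc(Cl)c(C)cc3O)=NN2c2ccc(S(N)(=O)=O)cc2)cc1OC`: in this assay compound 3 gives 6480 nM.

Compound 3 carries the highest of the three numbers, yet the gaps to it, a 1.3-fold higher number from compound 1 to compound 3 (0.10 log units; within the scatter) and a 1.8-fold higher number from compound 2 to compound 3 (0.25 log units; within the scatter), both lie within the scatter, so the three compounds cannot be told apart on these data. Compound 4, `COc1ccc(C2CC(c3cc(Cl)c(C)cc3O)=NN2c2ccc(S(N)(=O)=O)cc2)c(OC)c1OC`, differs from compound 3 by methoxy in place of hydrogen on an aromatic carbon. Going by the values given here, no measured step adds a group to the ring that sits on the saturated ring carbon; the two steps that touch that ring replace the whole group and stay within the scatter, as does a 1.4-fold lower number from compound 1 to compound 2 (0.15 log units; within the scatter) on the other ring. The step from compound 3 to compound 4 is therefore expected to be a 1.0-fold higher number from compound 3 to compound 4 (0.00 log units; within the scatter), nothing beyond the scatter. Compound 4 is estimated at 6500 nM, in the range 3000 nM to 14000 nM.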

Compound 4, concentration for total growth inhibition: 4280 nM
Compound 4: the middle estimate sits 1.5-fold (0.18 log units) above what was measured; the measured number falls inside the stated range.
By their numbers in this assay, from the lowest: compounds 2, 4, 1 and 3 (each within the scatter of the next).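

In this assay methoxy on this aromatic carbon, ortho to a large group, gives a 1.5-fold lower number from compound 3 to compound 4 (0.18 log units; within the scatter) and so shows that adding a group to this ring, rather than replacing the whole ring, also produces no difference beyond the scatter. Likewise, a 1.2-fold higher number from compound 2 to compound 4 (0.07 log units; within the scatter) and a 1.2-fold lower number from compound 1 to compound 4 (0.08 log units; within the scatter) stay within the scatter when 2,3,4-trimethoxyphenyl replaces 2-chlorophenyl or 2-hydroxyphenyl on the saturated ring carbon. On these data alone, whether an amine, a carboxylic acid or a longer chain at this aromatic carbon would move the number beyond the scatter remains open. Nothing measured here offers an explanation for these close numbers.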